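Lengthening a Side Chain Toward Compound 3

The source may hold more compounds than are shown below. What is called first, only, known or untested is meant among the compounds shown, and "the series" means these compounds.

Compound 1 `CCCCNC(=O)c1cc(C)sc1N`: >= 50000 nM
Compound 2 `CCCCNC(=O)c1cc(CCC)sc1N`: >= 50000 nM

In an assay on isolated protein for inhibition of Polyunsaturated fatty acid lipoxygenase ALOX15 (Homo sapiens), read by spectrophotometry, with a stated time of 10 min (on this read-out lower numbers stand for stronger inhibition and higher numbers for weaker inhibition), compound 1 gives >= 50000 nM, which is a limit of the assay rather than a number. Compound 2 likewise gives >= 50000 nM, again a limit. The step that the two limits leave unreadable from compound 1 to compound 2 therefore cannot be read, and the limit of >= 50000 nM in this assay, at which 2 of the 2 values shown sit, is all the measured pair shows. Compound 3 `CCCCCc1cc(C(=O)NCCCC)c(N)s1` carries ethyl in place of hydrogen on a saturated chain carbon, three bonds along the chain from an aromatic carbon. For the measured compounds named here, no measured step bears on this change with a readable size, so no shift beyond the scatter is expected, and another limit is the likely outcome. Compound 3 is estimated at 50000 nM, between 20000 nM and 200000 nM, an expected step of a number no higher from compound 2 to compound 3 (the limit leaves the size open).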

Compound 3, half-maximal inhibitory concentration: >= 50000 nM
Compound 3: a limit, no number; the forecaster's own chance of this, stated with the estimate: 85%; the middle value lies on the limit itself.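

Compound 1, compound 2 and compound 3 each give a limit rather than a number, so no step among them can be read: the limit of >= 50000 nM in this assay, at which 3 of the 3 values shown sit.

The compounds shown leave open whether side chain length on the shared core affects inhibition at all.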